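The compounds below may be only part of what the source reports. "The series", "measured", "known", "first", "only" and "open" are said of these compounds alone.

Measured in a functional assay on HCT-116 cells (Homo sapiens) for cytotoxicity, read by MTT assay, with a stated time of 48 h; a higher number here means a weaker inhibitor, a lower number a stronger inhibitor:
Compound 1 `COc1c(-c2ccccc2)c2ccccc2n(Cc2ccc(C(=O)NO)cc2)c1=O`: "not determined" (no result reported)
Compound 2 `CCN(CC)Cc1ccc(Cn2c(=O)c(OCc3ccc(C(=O)NO)cc3)c(-c3ccccc3)c3ccccc32)cc1`: 3600 nM

Compound 1 has no result, so compound 2 at 3600 nM stands alone on the numbers and is the only anchor. Compound 3 `CCN(CC)Cc1ccc(Cn2c(=O)c(OCc3ccc(C(=O)NO)cc3)c(-c3cccnc3)c3ccccc32)cc1` has pyridin-3-yl in place of phenyl on an aromatic carbon. Going by the values given here, no step between measured compounds shows what such a change does. In this assay, no shift beyond the scatter is expected, in either direction. The expected change is a 1.2-fold lower number from compound 2 to compound 3 (0.08 log units; within the scatter). For compound 3, the estimated value is 3000 nM, with an expected range of 1000 nM to 9000 nM.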

Compound 3, half-maximal inhibitory concentration: 8400 nM
Estimate against measurement, compound 3: 2.8-fold (0.45 log units) below, and the stated range covers the measured number.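

In this assay, this position now has its first reading: pyridin-3-yl in place of phenyl gives a 2.3-fold higher number from compound 2 to compound 3 (0.37 log units; beyond the scatter), so the exchange on this aromatic carbon, opposite the ring nitrogen, weakens the compound modestly. The position therefore responds to a ring nitrogen entering the aromatic substituent, though only to a small extent. No available evidence accounts for this shift.

The compounds shown leave open whether pyridin-4-yl or pyridin-2-yl would give the same result. They also leave open how a phenyl carrying an amine or a carboxylic acid would behave here.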